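The compounds below may be only part of what the source reports. "The series", "measured", "known", "first", "only" and "open" are said of these compounds alone.

Compound 1 `CCOC(=O)C1=C(Nc2ccccc2)S/C(=C\c2ccccc2)C1=O` gives 29.6% in a functional assay on A549 cells (Homo sapiens) for inhibition, read by MTT assay, with a stated time of 72 h, tested at 10 uM; on this read-out lower numbers stand for less inhibition and higher numbers for more inhibition at the one concentration tested (going by the name of the read-out). Compound 2 `CCOC(=O)C1=C(Nc2ccccc2)S/C(=C\c2cccnc2)C1=O` differs from it only in carrying pyridin-3-yl in place of phenyl on a double-bonded chain carbon bound to a double-bonded ring carbon, and in this assay compound 2 reaches < 10%. That value is a limit of the assay rather than a measured number, so compound 2 stands at the limit of < 10% in this assay, at which 1 of the 2 values shown sits, and its true reading could lie anywhere under that line. Among the measured compounds shown here, the step of a number at least 19.6 percentage points lower from compound 1 to compound 2 (beyond the scatter) is the single measured step here, and it shows that exchanging the aromatic ring at this position can shift the read-out well beyond the usual scatter. Compound 3 `CCOC(=O)C1=C(Nc2ccccc2)S/C(=C\c2cc3ccncc3[nH]2)C1=O` changes that same position once more: a group of 9 heavy atoms (7 carbon, 2 nitrogen; one five-membered aromatic ring with 1 hetero atom, one six-membered aromatic ring with 1 hetero atom) in place of a group of 6 heavy atoms (5 carbon, 1 nitrogen; one six-membered aromatic ring with 1 hetero atom), on a double-bonded chain carbon bound to a double-bonded ring carbon. For the measured compounds named here, no measured step covers an exchange of this kind, so the direction of the change is open; since compound 2 sits at the floor, any movement can only appear as an increase or as no change at all. The step of a number at least 5 percentage points higher from compound 2 to compound 3 (that floor lies within the scatter) is the change expected. For compound 3 the estimated value is 15%, within an expected range from 3% to 35%.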

Compound 3, a percentage reported as inhibition, at one concentration (the size of the read-out at that concentration, not a potency): 17.1%
Compound 3: middle estimate off by 2.1 percentage points, on the low side, within the range that was stated.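

Compound 3 shows that this place, on a double-bonded chain carbon bound to a double-bonded ring carbon, can carry a larger group with two aromatic rings and a hydrogen-bond donor and still give a reading in this assay, with a number at least 7.1 percentage points higher from compound 2 to compound 3 (that floor lies within the scatter). Compound 2 has a limit of the assay rather than a number, so this step gives no exact size and does not establish a real rise: the limit of < 10% in this assay, at which 1 of the 3 values shown sits. Compared with the plain phenyl ring of compound 1, the new group gives a number 12.5 percentage points lower from compound 1 to compound 3 (beyond the scatter), so both replacements of phenyl shown here, pyridin-3-yl and the two-ring group, give lower numbers than phenyl, and neither restores its reading.

The two-ring group brings a second ring and a hydrogen-bond donor together, and the compounds shown do not separate their contributions to the reading. Also open, as far as these compounds go, is how the reading would respond to an amine or a carboxylic acid on the phenyl ring of compound 1, which would show whether a substituted phenyl can go beyond the unsubstituted one.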